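The compounds below may be only part of what the source reports. "The series", "measured", "known", "first", "only" and "open" are said of these compounds alone.

Compound 3 `CNC(=O)c1ccccc1Oc1nc(Nc2cccc(OC)c2)ncc1Br` gives the lowest number of the three measured compounds in a functional assay on HL-60 cells (Homo sapiens) for antiproliferative activity, read by MTT assay, with a stated time of 24 h (a higher number here means a weaker inhibitor, a lower number a stronger inhibitor), namely 16200 nM. Compound 1 `CNC(=O)c1ccccc1Oc1nc(Nc2ccc(Br)cc2)ncc1Br` gives 39700 nM in this assay, and compound 2 `CNC(=O)c1ccccc1Oc1nc(Nc2cccc(Br)c2)ncc1Br` gives 38700 nM; the step of a 1.0-fold lower number from compound 1 to compound 2 (0.01 log units; within the scatter) is within the scatter, while a 2.5-fold lower number from compound 1 to compound 3 (0.39 log units; beyond the scatter) and a 2.4-fold lower number from compound 2 to compound 3 (0.38 log units; beyond the scatter) are modest and beyond it.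

Compound 4 `CNC(=O)c1ccccc1Oc1nc(Nc2cccc(C(C)C)c2)ncc1Br` differs from compound 3 by the change (isopropyl in place of methoxy on an aromatic carbon), that is, isopropyl in place of methoxy on an aromatic carbon, meta to a large group. Going by the values given here, the only measured step at this position is a 2.4-fold lower number from compound 2 to compound 3 (0.38 log units; beyond the scatter), which shows that exchanging one group for another there moves this assay by a modest amount. Among the compounds with values here, no measured compound carries isopropyl, so the direction of the new step is not fixed by the data. The step of a 1.4-fold higher number from compound 3 to compound 4 (0.13 log units; within the scatter) is therefore expected to be small, most likely within the scatter, with a somewhat higher number as the more probable outcome. Compound 4 is estimated to give 22000 nM in this assay, with a range from 8000 nM to 55000 nM.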

Compound 4, half-maximal inhibitory concentration: 17500 nM
Compound 4: the middle estimate sits 1.3-fold (0.10 log units) above what was measured; the measured number falls inside the stated range.
By their numbers in this assay, from the lowest: compounds 3 and 4 (each within the scatter of the next); then compounds 2 and 1 (each within the scatter of the next).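

In this assay, the change from 3-methoxyphenyl to 3-isopropylphenyl gives a 1.1-fold higher number from compound 3 to compound 4 (0.03 log units; within the scatter), so at this position a group with no hydrogen-bond acceptor and one with a hydrogen-bond acceptor cannot be told apart. Isopropyl in place of bromo on the same aromatic carbon gives a 2.2-fold lower number from compound 2 to compound 4 (0.34 log units; beyond the scatter), and 3-isopropylphenyl in place of 4-bromophenyl gives a 2.3-fold lower number from compound 1 to compound 4 (0.36 log units; beyond the scatter), so among these four compounds the methoxy and isopropyl compounds both stand apart from the bromo compounds. Nothing outside these numbers is at hand to explain this.

On these data alone, whether an amine, a carboxylic acid or a longer chain on this carbon would stay level with methoxy and isopropyl remains open. As far as these compounds go, it is also open whether methoxy or isopropyl would give the same result where compound 1 carries its bromo.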